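Replacing the 4-(dimethylamino)phenyl group of compound 2

The source may hold more compounds than are shown below. What is called first, only, known or untested is meant among the compounds shown, and "the series" means these compounds.

In a functional assay on DU-145 cells (Homo sapiens) for inhibition, read by trypan blue exclusion, with a stated time of 96 h (on this read-out higher numbers stand for weaker inhibition of growth and lower numbers for stronger inhibition of growth), compound 2 `CN(C)c1ccc(/C=C(/SCc2ccc(F)cc2)C(=O)c2ccc(Br)cc2)cc1` gives 50000 nM, the higher of the two numbers, and compound 3 `CN(C)c1ccc(/C=C(/SCc2ccc(F)cc2)C(=O)c2ccc(C(=O)O)cc2)cc1` gives 10000 nM. Compound 1 `CN(C)c1ccc(/C=C(/Sc2ccccc2Br)C(=O)c2ccc(Br)cc2)cc1` reports only a limit, > 100000 nM.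

Compound 4 `Cc1cc(F)ccc1/C=C(/SCc1ccc(F)cc1)C(=O)c1ccc(Br)cc1` differs from compound 2 by 4-fluoro-2-methylphenyl in place of 4-(dimethylamino)phenyl on a double-bonded chain carbon bound to a double-bonded chain carbon.

Neither measured step touches this group. The step of an at least 2.0-fold lower number from compound 1 to compound 2 (0.30 log units; that floor lies within the scatter) has a floor within the scatter, and the step of a 5.0-fold lower number from compound 2 to compound 3 (0.70 log units; beyond the scatter) is modest but beyond it. Going by the values given here, with no measured precedent at this place, no shift beyond the scatter is expected in this assay, though uncertainty is wide. The expected size is a 1.7-fold lower number from compound 2 to compound 4 (0.22 log units; within the scatter). For compound 4 the estimate is 30000 nM, with an expected range of 6000 nM to 100000 nM.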

Compound 4, concentration for 50% growth inhibition: 10000 nM
The estimate for compound 4 lay 3.0-fold (0.48 log units) above the measured number; the range from low to high includes it.
By their numbers in this assay, from the lowest: compounds 3 and 4 (each within the scatter of the next); then compound 2. At a limit, above all of these: compound 1.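

The place on the double-bonded chain carbon turns out to respond in this assay: 4-fluoro-2-methylphenyl in place of 4-(dimethylamino)phenyl gives a 5.0-fold lower number from compound 2 to compound 4 (0.70 log units; beyond the scatter). An amine on this aryl group is therefore not required for this level of growth inhibition, at least in compound 4. No measurement shown gives a cause for this step.

As far as these compounds go, it remains open whether this change and the carboxy in place of bromo combine in one compound. Also open, from the compounds shown here alone, is how a carboxylic acid or a morpholine would behave at this place.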